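Anilino Series on the Shared Core: Aryl Swap

The source may hold more compounds than are shown below. What is called first, only, known or untested is meant among the compounds shown, and "the series" means these compounds.

Among the compounds with values here, compound 1 `O=C1C=C(Nc2cccc(Cl)c2)C(=O)c2c1nc1n2[C@H]2OC[C@@H](O)[C@H]2OC1` gives 1770 nM in a functional assay on MGC-803 cells (Homo sapiens) for inhibition, read by sulforhodamine B assay (a lower number here means a stronger inhibitor, a higher number a weaker inhibitor), and stands as the only finite number among the values shown. Compound 2 `O=C1C(N2CCCC2)=CC(=O)c2c1nc1n2[C@H]2OC[C@@H](O)[C@H]2OC1` returns only a limit of this assay, > 16000 nM, where one of the two values sits (the limit of > 16000 nM in this assay, at which 1 of the 2 values shown sits). Compound 3 `O=C1C=C(Nc2ccccc2F)C(=O)c2c1nc1n2[C@H]2OC[C@@H](O)[C@H]2OC1` differs from compound 1 by 2-fluorophenyl in place of 3-chlorophenyl on an amine nitrogen, the amine itself being kept. Within the data shown here, no step between measured compounds is available, so the change is expected to move this assay only modestly, and if at all toward a weaker inhibitor; the expected step is a 1.7-fold higher number from compound 1 to compound 3 (0.23 log units; within the scatter). Compound 3 is therefore estimated at 3000 nM, between 1000 nM and 10000 nM.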

Compound 3, half-maximal inhibitory concentration: 2080 nM
Estimate against measurement, compound 3: 1.4-fold (0.16 log units) above; measured number inside the range.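

On the amine nitrogen, 2-fluorophenyl and 3-chlorophenyl are interchangeable in this assay, with a 1.2-fold higher number from compound 1 to compound 3 (0.07 log units; within the scatter). This swap changes both the halogen and where it sits on the ring, and the pair gives no separate reading of either change. Nothing measured here bears on why the number holds.

Still open, on these data alone, is how unsubstituted phenyl compares on the same amine nitrogen. Also open, as far as these compounds go, is whether a phenyl carrying a methoxy group or a carboxylic acid, or a pyridine ring, keeps the number in the same range.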